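Nitro for acetyl on the shared core: a cytotoxicity estimate

The source may report more compounds than this note shows. Statements on the series, on what has been measured and on what is new or still open speak of the compounds shown alone.

compound 1 `COc1ccc(-c2nc3cc(C(C)=O)ccc3[nH]2)c(OC)c1OC` — > 100000 nM
compound 2 `Fc1cccc(F)c1-c1nc2cc(Cl)c(Cl)cc2[nH]1` — 43000 nM
compound 3 `CCC(=O)Nc1ccc(-c2nc3cc(C(F)(F)F)ccc3[nH]2)cc1` — > 100000 nM

All three were tested in an ADME assay on MDBK cells (Bos taurus) for cytotoxicity, read by MTT assay, with a stated time of 96 h; on this read-out lower numbers stand for higher toxicity in this test and higher numbers for lower toxicity in this test. For compound 1 the value > 100000 nM is a limit of the assay, not a number. Compound 3 likewise sits at a limit, > 100000 nM. Compound 2 gives 43000 nM in this assay. Compound 1 thus stands at the assay limit, where two of the three values sit (the limit of > 100000 nM in this assay, at which 2 of the 3 values shown sit). Compound 4 `COc1ccc(-c2nc3cc([N+](=O)[O-])ccc3[nH]2)c(OC)c1OC` differs from compound 1 by nitro in place of acetyl on an aromatic carbon. For the measured compounds named here, no measured step between two compounds shows how such a change plays out here. The expected step is a number no higher from compound 1 to compound 4 (the limit leaves the size open), none beyond the scatter, with a good chance that only a limit is reported again. The estimate for compound 4 in this assay is 100000 nM, within 30000 nM to 300000 nM.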

Compound 4, half-maximal cytotoxic concentration: > 100000 nM
Compound 4: no number, only a limit; the forecaster's own chance of this, stated with the estimate: 60%; the middle value sits exactly at the limit.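

No step can be read between compound 1 and compound 4 in this assay, since each gives only a limit: the limit of > 100000 nM in this assay, at which 3 of the 4 values shown sit.

The compounds shown leave open whether nitro in place of acetyl changes the read-out at all.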